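Amide substituent swap on a shared kinase-inhibitor core

The compounds below may be only part of what the source reports. "The series", "measured", "known", "first", "only" and "open" are said of these compounds alone.

Compound 3 `CC(=O)N1CC(NC(=O)c2ccncc2Nc2cc(-c3ccc4ccn(C)c4c3)c3nccnc3c2)C1` gives 73 nM in an assay for inhibition of 6-phosphofructo-2-kinase/fructose-2,6-bisphosphatase 3 (Homo sapiens), read by ADP-Glo, with a stated time of 2 h (a higher number here means a weaker inhibitor, a lower number a stronger inhibitor), the highest number among the three measured compounds. Compound 1 `Cn1ccc2ccc(-c3cc(Nc4cnccc4C(=O)NC4CCNC(=O)C4)cc4nccnc34)cc21` gives 69 nM, and the step of a 1.1-fold higher number from compound 1 to compound 3 (0.02 log units; within the scatter) lies within the scatter. Compound 2 `CC(=O)N1CCCC(NC(=O)c2ccncc2Nc2cc(-c3ccc4ccn(C)c4c3)c3nccnc3c2)C1` gives 11 nM; the steps of a 6.3-fold lower number from compound 1 to compound 2 (0.80 log units; beyond the scatter) and a 6.6-fold higher number from compound 2 to compound 3 (0.82 log units; beyond the scatter) are both beyond the scatter. Compound 4 `CN1CCC(CNC(=O)c2ccncc2Nc2cc(-c3ccc4ccn(C)c4c3)c3nccnc3c2)C1` differs from compound 3 in that ((1-methylpyrrolidin-3-yl)methyl in place of 1-acetylazetidin-3-yl on an amide-type nitrogen). Within the data shown here, no measured step places this exact group on the amide-type nitrogen; the only guidance is that the five-membered ring of compound 4 sits between the four-membered ring of compound 3 and the 1-acetylpiperidin-3-yl of compound 2, whose step was modest. Compound 4 is therefore expected to show a modest step of a 2.1-fold lower number from compound 3 to compound 4 (0.32 log units; beyond the scatter) in this assay, estimated at 35 nM with a range of 10 nM to 120 nM.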

Compound 4, half-maximal inhibitory concentration: 74 nM
For compound 4 the middle estimate is 2.1-fold (0.33 log units) below the measured one; measured number inside the range.
By their numbers in this assay, from the lowest: compound 2; then compounds 1, 3 and 4 (each within the scatter of the next).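

In this assay, the (1-methylpyrrolidin-3-yl)methyl group, which has no oxygen, reads level with two oxygen-bearing groups on the amide-type nitrogen: a 1.0-fold higher number from compound 3 to compound 4 (0.01 log units; within the scatter) and a 1.1-fold higher number from compound 1 to compound 4 (0.03 log units; within the scatter) both lie within the scatter. Against this, a 6.7-fold higher number from compound 2 to compound 4 (0.83 log units; beyond the scatter) lies beyond the scatter, so among the four compounds the 1-acetylpiperidin-3-yl group of compound 2 alone stands apart. From the compounds shown here alone, whether a 1-acetylpyrrolidin-3-yl or 1-methylpiperidin-3-yl group would match compound 2 remains open. Nothing available here explains why these groups fall as they do.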